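A few compounds are considered here, and "the series" means these few. Any claim that something is new, unique, unknown or untested is made for them only; others in the source may bear on it.

Measured compounds:
compound 1 `C[C@H](NC(=O)c1c(C(F)(F)F)nnn1Cc1ccc(C(F)(F)F)cc1)c1ccc(C(=O)O)cc1`: in a functional assay on CHO cells for antagonist activity at prostaglandin E2 receptor EP4 subtype (Homo sapiens), read by calcium flux, with a stated time of 15 min (on this read-out lower numbers stand for stronger inhibition and higher numbers for weaker inhibition), compound 1 gives 225 nM
compound 2 `CCc1nnn(Cc2ccc(C(F)(F)F)cc2)c1C(=O)N[C@@H](C)c1ccc(C(=O)O)cc1`: compound 2 gives > 10000 nM, which is a limit of the assay and not a number
compound 3 `CCCc1nnn(Cc2ccc(C(F)(F)F)cc2)c1C(=O)N[C@@H](C)c1ccc(C(=O)O)cc1`: compound 3 gives 68.8 nM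

Compound 3 holds the lowest of the two numbers shown; its nearest neighbour is compound 1, and the step of a 3.3-fold lower number from compound 1 to compound 3 (0.51 log units; beyond the scatter) is beyond the scatter. Compound 2 sits at the limit of > 10000 nM in this assay, at which 1 of the 3 values shown sits.

Compound 4 `C[C@H](NC(=O)c1c(C2CCC2)nnn1Cc1ccc(C(F)(F)F)cc1)c1ccc(C(=O)O)cc1` differs from compound 3 in one place: cyclobutyl in place of propyl on an aromatic carbon.

Within the data shown here, three measured steps touch this position on the shared core. From propyl to an ethyl chain the number jumps: an at least 140-fold lower number from compound 2 to compound 3 (2.16 log units; beyond the scatter). From trifluoromethyl to propyl it falls: a 3.3-fold lower number from compound 1 to compound 3 (0.51 log units; beyond the scatter). From trifluoromethyl to ethyl it climbs: an at least 44-fold higher number from compound 1 to compound 2 (1.64 log units; beyond the scatter). Together they show that this position is very sensitive, and that the sizes measured so far are not all in one direction. Cyclobutyl is a new kind of group here, a ring where a chain stood, so its effect cannot be read straight from these steps.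

Compound 4 is therefore expected to land near compound 3, with the step of a 1.7-fold higher number from compound 3 to compound 4 (0.24 log units; within the scatter) judged likely small but uncertain in direction. The estimate for compound 4 is 120 nM, with a range from 30 nM to 700 nM.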

Compound 4, half-maximal inhibitory concentration: 75.3 nM
The estimate for compound 4 lay 1.6-fold (0.20 log units) above the measured number, and the stated range covers the measured number.
By their numbers in this assay, from the lowest: compounds 3 and 4 (each within the scatter of the next); then compound 1. At a limit, above all of these: compound 2.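

In this assay, a four-membered carbon ring on this aromatic carbon cannot be told apart from the propyl chain, the step being a 1.1-fold higher number from compound 3 to compound 4 (0.04 log units; within the scatter), so an open chain is not needed here. Cyclobutyl also stands clear of the other two groups measured at this position, with an at least 130-fold lower number from compound 2 to compound 4 (2.12 log units; beyond the scatter) and a 3.0-fold lower number from compound 1 to compound 4 (0.48 log units; beyond the scatter), which matches the picture already given by propyl. The value for compound 2 remains a limit of the assay and not a number: the limit of > 10000 nM in this assay, at which 1 of the 4 values shown sits.

The compounds shown leave open how far this match between a chain and a ring extends, since a cyclopropyl ring, a cyclopentyl ring or a butyl chain at the same position could each fall close to compounds 3 and 4 or far from them. They also leave open why ethyl stands so far from propyl and cyclobutyl, and a methyl group or an isopropyl group here would help to show where along this series the sharp divide between the numbers lies.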